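A few compounds are considered here, and "the series" means these few. Any claim that something is new, unique, unknown or untested is made for them only; others in the source may bear on it.

Compound 1 `COc1ccc(-c2cccc(NC(=O)C(Cl)Cl)c2)cc1`: > 50000 nM
Compound 2 `O=C(Nc1cccc(-c2cccs2)c1)C(Cl)Cl`: > 50000 nM

Both compounds were tested in a functional assay on KB 3-1 cells (Homo sapiens) for cytotoxicity, read by MTT assay, with a stated time of 68 h; a lower number here means a stronger inhibitor, a higher number a weaker inhibitor. In this assay, compound 1 gives > 50000 nM, which is a limit of the assay and not a number. Compound 2 gives > 50000 nM, which is also a limit. Compound 1 therefore has no exact position, and the record so far reads: the limit of > 50000 nM in this assay, at which 2 of the 2 values shown sit.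

Compound 3 `O=C(Nc1cccc(-c2ccc(C(F)(F)F)cc2)c1)C(Cl)Cl` has trifluoromethyl in place of methoxy on an aromatic carbon, para to a large group: trifluoromethyl in place of methoxy on an aromatic carbon. Going by the values given here, no measured step shows what this change does in this assay. The expectation is no step beyond the usual scatter, with another limit being a likely result. This expectation rests on compound 1, whose > 50000 nM is a limit. The estimated step is a number no higher from compound 1 to compound 3 (the limit leaves the size open). For compound 3, the estimated value is 50000 nM, with an expected range from 15000 nM to 100000 nM.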

Compound 3, half-maximal inhibitory concentration: > 50000 nM
Compound 3: a limit, no number (the forecaster's own chance of this, stated with the estimate: 65%); the middle value lies on the limit itself.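

Going by these compounds alone, compound 3 ends at a limit of the assay, as compound 1 does, so no step from compound 1 to compound 3 can be read. The compounds shown leave open which change, if any, would give a measurable value, as all share one result: the limit of > 50000 nM in this assay, at which 3 of the 3 values shown sit.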